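The source may report more compounds than this note shows. Statements on the series, on what has been measured and on what is new or still open speak of the compounds shown alone.

Compound 1 `CCOCCOC(=O)Nc1cc2nc(C3CCCCC3)[nH]c2cc1N(C)C`: in an ADME assay on Vero cells (Chlorocebus sabaeus) for cytotoxicity, read by resazurin assay, with a stated time of 3 days (a higher number here means a weaker inhibitor, a lower number a stronger inhibitor), compound 1 gives > 100 ug/mL, which is a limit of the assay rather than a number.
Compound 2 `CN(C)c1cc2[nH]c(C3CCCCC3)nc2cc1NC(=O)c1ccc(OC(F)F)cc1`: in this assay compound 2 gives > 100 ug/mL, again a limit and not a number.

Both measured values sit at the limit of > 100 ug/mL in this assay, at which 2 of the 2 values shown sit, so compound 2 stands at the limit and nothing more is known of where it lies. Going by the values given here, the only measured step, a step that the two limits leave unreadable from compound 1 to compound 2, has limits at both ends and yields no readable size. Compound 3 `CCc1ccc(C(=O)Nc2cc3nc(C4CCCCC4)[nH]c3cc2N(C)C)cc1` differs from compound 2 by ethyl in place of difluoromethoxy on an aromatic carbon. Among the compounds with values here, no measured step bears on this change, and the single step that exists gives no size to work from. Since both measured compounds reached the limit, compound 3 is expected to reach it too, and the step that the limit leaves unreadable from compound 2 to compound 3 is expected to be none beyond the scatter. Compound 3 is therefore estimated at 150 ug/mL, with a range from 60 ug/mL to 400 ug/mL, and most likely reported only as a limit.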

Compound 3, half-maximal inhibitory concentration: > 100 ug/mL
Compound 3 gave a limit, no number (the forecaster's own chance of this, stated with the estimate: 75%); the middle value does not contradict the limit.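

Going by these compounds alone, no step among compound 1, compound 2 and compound 3 can be read in this assay, since all three give a limit and not a number: the limit of > 100 ug/mL in this assay, at which 3 of the 3 values shown sit.
The compounds shown leave open how far past that limit each one lies, and whether changing the group on the carbonyl carbon alters the read-out at all.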